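A few compounds are considered here, and "the series" means these few. Any claim that something is new, unique, unknown or untested is made for them only; others in the source may bear on it.

Measured so far:
- compound 1 `COc1ccc(C2C(C#N)=C(N)N(c3cc(OC)c(OC)c(OC)c3)C3=C2C(=O)CC(C)(C)C3)cc1`: in a functional assay on Ehrlich cells (Mus musculus) for cytotoxicity, tested at 100 ug/mL (a lower number here means a weaker effect, a higher number a stronger effect of the compound at the concentration tested), compound 1 gives 15%
- compound 2 `COc1cc(N2C(N)=C(C#N)C(c3c(OC)ccc4ccccc34)C3=C2CC(C)(C)CC3=O)cc(OC)c1OC`: in this assay compound 2 gives 30%

Compound 1 stands at the lowest of the two numbers in this assay. Among the measured compounds shown here, its only neighbor is compound 2, and the single measured step, a number 15 percentage points higher from compound 1 to compound 2 (beyond the scatter), is beyond the scatter and modest in size.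

Compound 3 `COc1cc(N2C(N)=C(C#N)C(c3c(O)ccc4ccccc34)C3=C2CC(C)(C)CC3=O)cc(OC)c1OC` has not been measured in this assay. It differs from compound 1 in one place: 2-hydroxynaphthalen-1-yl in place of 4-methoxyphenyl on a saturated ring carbon

The step that bears on this change is a number 15 percentage points higher from compound 1 to compound 2 (beyond the scatter), since it also replaces 4-methoxyphenyl on the same saturated ring carbon with a naphthalenyl group. For the measured compounds named here, the incoming group of compound 3 differs from that of compound 2 only in carrying a hydroxy instead of a methoxy on the naphthalene; no measured pair shows what that exchange does in this assay. Going by the values given here, the expectation therefore leans on the one measured step, and a rise of similar size, a number 15 percentage points higher from compound 1 to compound 3 (beyond the scatter), is expected for compound 3. The estimate for compound 3 in this assay is 30%, within a range of 15% to 45%.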

Compound 3, a percentage reported as activity, at one concentration (the size of the read-out at that concentration, not a potency): 90%
Beside the measured number, compound 3's estimate is 60 percentage points below it; measured number above the stated range.
By their numbers in this assay, from the lowest: compound 1; then compound 2; then compound 3.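

In this assay the group on the saturated ring carbon can carry a far larger effect than the first naphthalenyl step suggested: 2-hydroxynaphthalen-1-yl in place of 4-methoxyphenyl gives a number 75 percentage points higher from compound 1 to compound 3 (beyond the scatter) in the shared core. Most of that rise belongs to one small change on the naphthalene, since hydrogen in place of methyl on the oxygen gives a number 60 percentage points higher from compound 2 to compound 3 (beyond the scatter) and the added ring with the methoxy group kept gives only a number 15 percentage points higher from compound 1 to compound 2 (beyond the scatter) so the free hydroxy group and the second aromatic ring do not contribute equally in these compounds. Nothing at hand accounts for why losing this one methyl group changes the read-out so strongly.

Open, from the compounds shown here alone, is whether the hydroxy group needs the naphthalene at all, which a 4-hydroxyphenyl group on the same carbon would show, and whether a 2-aminonaphthalen-1-yl group would match the hydroxy compound. Going by these compounds, all three numbers also come from a single concentration, so how far compound 3 stands from the others in potency remains open.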